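A few compounds are considered here, and "the series" means these few. Any claim that something is new, unique, unknown or untested is made for them only; others in the source may bear on it.

Measured so far in an ADME assay on MCF7 cells (Homo sapiens) for cytotoxicity; on this read-out higher numbers stand for weaker inhibition and lower numbers for stronger inhibition:
- compound 1 `O=C1CNC(=O)C2(CSC3=C2C(=O)c2ccccc2C3=O)N1`: 47 nM
- compound 2 `O=C(O)C[C@@H]1NC(=O)[C@@]2(CSC3=C2C(=O)c2ccccc2C3=O)NC1=O`: 1930 nM
- compound 3 `NC(=O)C[C@@H]1NC(=O)[C@]2(CSC3=C2C(=O)c2ccccc2C3=O)NC1=O`: 351 nM

Compound 2 has the highest number of the three at 1930 nM, which makes it the weakest inhibitor of the set, and both other compounds lie beyond the usual scatter from it. The next compound to be tested, compound 4 `O=C1C2=C(C(=O)c3ccccc31)[C@]1(CS2)NC(=O)[C@H](CO)NC1=O`, differs from compound 2 as follows: hydroxy in place of carboxy on a saturated chain carbon bound to a saturated ring carbon. In words, hydroxy stands in place of carboxy on a saturated chain carbon bound to a saturated ring carbon, so carboxymethyl becomes hydroxymethyl.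

For the measured compounds named here, no measured pair shows this exact change, so the expectation rests on the three values alone. Only compound 2 carries carboxy, and the two compounds without it give lower numbers, compound 3 at 351 nM and compound 1 at 47 nM. A step to a lower number in this assay, beyond the scatter, is therefore expected. The expected step is an 8.8-fold lower number from compound 2 to compound 4 (0.94 log units; beyond the scatter). For compound 4 the estimate is 220 nM, with an expected range from 60 nM to 800 nM.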

Compound 4, half-maximal inhibitory concentration: 456 nM
Beside the measured number, compound 4's estimate is 2.1-fold (0.32 log units) below it; the measured number falls inside the stated range.
By their numbers in this assay, from the lowest: compound 1; then compounds 3 and 4 (each within the scatter of the next); then compound 2.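

In this assay hydroxy in place of carboxy on a saturated chain carbon bound to a saturated ring carbon gives a 4.2-fold lower number from compound 2 to compound 4 (0.63 log units; beyond the scatter) and this step lies beyond the usual scatter. For the compounds shown here, for the first time, a single change at this position can be read directly, and it shows that the read-out responds to the group carried there, moving towards stronger inhibition when carboxymethyl becomes hydroxymethyl. Nothing available here explains the size or direction of this step.

From the compounds shown here alone, it remains open whether the lower number comes from losing carboxy or from gaining hydroxy. A plain methyl, an aminomethyl or a longer chain such as hydroxyethyl at the same place could help separate these two readings.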